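Series notes: from 2-hydroxyphenyl to 4-aminophenyl

This account rests on a few compounds, and the source may have more. Where it says the series, first, only, none or still open, it means among the compounds named here.

Values in a functional assay on MDA-MB-231 cells (Homo sapiens) for cytotoxicity, read by MTT assay, with a stated time of 48 h; a higher number here means a weaker inhibitor, a lower number a stronger inhibitor:
- compound 1 `Fc1cccc(Nc2nc(-c3cccc(F)c3)nc3ccc(F)cc23)c1` gives 47600 nM
- compound 2 `Oc1ccccc1Nc1nc(-c2cccc(F)c2)nc2ccc(F)cc12` gives > 50000 nM
- compound 3 `Nc1ccc(Nc2nc(-c3cccc(F)c3)nc3ccc(F)cc23)cc1` is not yet measured

Compound 2 has no number, and its entry of > 50000 nM is a limit. It sits at the limit of > 50000 nM in this assay, at which 1 of the 2 values shown sits, in the data so far.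

The next change, counted as 4-aminophenyl in place of 2-hydroxyphenyl on a nitrogen on an aromatic ring, puts 4-aminophenyl in place of 2-hydroxyphenyl on a nitrogen on an aromatic ring. Among the measured compounds shown here, one measured step bears on this place, an at least 1.0-fold higher number from compound 1 to compound 2 (0.02 log units; that floor lies within the scatter), and it is only a floor. It says nothing about the 4-aminophenyl group, so it supports no expectation of a large move in this assay. A small shift toward a lower number remains possible, and none beyond the scatter is expected, with an estimated at least 1.7-fold lower number from compound 2 to compound 3 (0.25 log units; that floor lies within the scatter) as the size.

For compound 3 the estimate is 28000 nM, with an expected range from 8000 nM to 50000 nM in this wide band.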

Compound 3, half-maximal inhibitory concentration: > 50000 nM
Compound 3: no number, only a limit (the forecaster's own chance of this, stated with the estimate: 35%); middle value at least 1.7-fold (0.25 log units) from the limit.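

In this assay compound 3 gives > 50000 nM, which is a limit and not a number. Against the 3-fluorophenyl group, 4-aminophenyl on this nitrogen gives an at least 1.0-fold higher number from compound 1 to compound 3 (0.02 log units; that floor lies within the scatter), so this change yields only a floor, and the step between the two compounds held at the limit cannot be read. Among the compounds shown here, both 2-hydroxyphenyl and 4-aminophenyl now end without a number at this position, and the limit accounts for most of the series so far: the limit of > 50000 nM in this assay, at which 2 of the 3 values shown sit.

As far as these compounds go, how far compound 2 and compound 3 lie from each other remains open. Also open, from the compounds shown here alone, is whether a benzyl group, a carboxylic acid-bearing phenyl or a saturated amine such as morpholine on this nitrogen would give a clearly lower value than compound 1. Compound 1 gives 47600 nM.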